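A methylsulfanyl swap on compound 2

The source may report more compounds than this note shows. Statements on the series, on what has been measured and on what is new or still open speak of the compounds shown alone.

In an in vivo ADME assay on the whole organism for pharmacokinetics, with Mus musculus as the target, at a dose of 200 mg/kg by the intraperitoneal route (on this read-out lower numbers stand for lower exposure and higher numbers for higher exposure at the dose given), compound 1 `COc1ccc(C2=C(c3ccc(SC)cc3)CC3CCCN3C2=O)cc1OC` gives 23000 nM and compound 2 `CSc1ccc(C2=C(c3ccc(C(F)(F)F)cc3)C(=O)N3CCCC3C2)cc1` gives 3790 nM, the lower of the two numbers by a gap beyond the usual scatter. Compound 3 `CSc1ccc(C2=C(c3ccc(SC)cc3)C(=O)N3CCCC3C2)cc1` has methylsulfanyl in place of trifluoromethyl on an aromatic carbon of compound 2 (methylsulfanyl in place of trifluoromethyl on an aromatic carbon). Among the compounds with values here, no step between measured compounds covers this change. Compound 1 also carries methylsulfanyl and stands at 23000 nM, so a moderate rise in this assay is expected. The expected change is a 2.1-fold higher number from compound 2 to compound 3 (0.32 log units; beyond the scatter). For compound 3 the estimated value is 8000 nM, with an expected range from 3000 nM to 22000 nM.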

Compound 3, maximal plasma concentration: 860 nM
For compound 3 the middle estimate is 9.3-fold (0.97 log units) above the measured one, outside the stated range (below it).
By their numbers in this assay, from the lowest: compound 3; then compound 2; then compound 1.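

Methylsulfanyl in place of trifluoromethyl, on an aromatic carbon para to a large group, gives a 4.4-fold lower number from compound 2 to compound 3 (0.64 log units; beyond the scatter) in this assay and so lowers exposure at the dose given. Within the data shown here, this is the first step in the set that isolates a single change, and it shows that the group at this position alone can shift the number beyond the usual scatter. No measured evidence accounts for the drop.

On these data alone, whether an amine or a carboxylic acid at this position would raise or lower the number remains open. So does whether this swap would act the same way on a different core.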